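The source may report more compounds than this note shows. Statements on the series, on what has been measured and on what is new or still open speak of the compounds shown alone.

Compound 3 `COc1cc(Cl)cc(-c2nn(-c3cccc(NC(=O)Nc4cccc(C(F)(F)F)c4)c3)cc2-c2ccncc2)c1` was tested in a functional assay on UO-31 cells (Homo sapiens) for inhibition, read by sulforhodamine B assay, with a stated time of 48 h, tested at 0.01 uM (a higher number here means a weaker effect of the compound at the concentration tested, a lower number a stronger effect), and gives 91%. Compound 1 `COc1cc(Cl)cc(-c2nn(-c3cccc(NC(=O)Nc4ccc(Cl)c(C(F)(F)F)c4)c3)cc2-c2ccncc2)c1` gives 91% in this assay, and compound 2 `COc1cc(Cl)cc(-c2nn(-c3cccc(NC(=O)Nc4ccc(Cl)c(Cl)c4)c3)cc2-c2ccncc2)c1` gives 89%. Compound 3 thus stands level with compound 1 at the digits printed and within the scatter of compound 2: the three numbers sit close together, with no change at the digits printed from compound 1 to compound 3 (within the scatter), a number 2 percentage points lower from compound 1 to compound 2 (within the scatter) and a number 2 percentage points higher from compound 2 to compound 3 (within the scatter).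

Compound 4 `COc1cc(Cl)cc(-c2nn(-c3cccc(NC(=O)c4cccc(C(F)(F)F)c4)c3)cc2-c2ccncc2)c1` has not yet been measured in this assay. It differs from compound 3 in one place: 3-(trifluoromethyl)phenyl in place of (3-(trifluoromethyl)phenyl)amino on a carbonyl carbon. None of the three measured steps bears directly on this change; each of them varies only a group on an aromatic carbon or the whole aryl on the amide-type nitrogen, and all of them stayed within the scatter. Within the data shown here, there is no measured step that shows what the loss of the amino link on the carbonyl carbon does in this assay. With the three measured compounds all close together at this concentration, compound 4 is expected to sit with them, and the step of a number 1 percentage points lower from compound 3 to compound 4 (within the scatter) is expected to stay within the scatter. Compound 4 is therefore estimated to give 90% in this assay, with a range from 78% to 100%.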

Compound 4, a percentage reported as activity, at one concentration (the size of the read-out at that concentration, not a potency): 58%
Compound 4: the middle estimate sits 32 percentage points above what was measured, and the stated range ends above it.
By their numbers in this assay, from the lowest: compound 4; then compounds 2, 1 and 3 (each within the scatter of the next).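

In this assay, among these compounds, the carbonyl carbon is the first place where a change moves the number beyond the scatter: a number 33 percentage points lower from compound 3 to compound 4 (beyond the scatter), and the other two comparisons agree, with a number 31 percentage points lower from compound 2 to compound 4 (beyond the scatter) and a number 33 percentage points lower from compound 1 to compound 4 (beyond the scatter). The earlier steps shown here on the outer aryl group all stayed within the scatter, whereas compound 3 and compound 4 carry the same 3-(trifluoromethyl)phenyl group, so the stronger effect at this concentration goes with the loss of the amino link and its amide hydrogen, a change to which this position is clearly sensitive. Nothing available explains this shift.

The compounds shown leave open whether the stronger effect follows from the shorter link or from the absence of the amide hydrogen, a question that a methylene group or an oxygen atom in place of the amino link would help to separate. Also open, on these data alone, is whether 4-chloro-3-(trifluoromethyl)phenyl and 3,4-dichlorophenyl, which gave numbers within the scatter of one another on the amino link, would still do so when attached directly to the carbonyl carbon.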